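A few compounds are considered here, and "the series" means these few. Any claim that something is new, unique, unknown or untested is made for them only; others in the source may bear on it.

Three compounds share one core and differ only in the aryl group on the sulfonyl sulfur. Compound 1 `O=S(=O)(Nc1ccc(-c2nc3ccccc3o2)cc1)c1cccc(F)c1` carries a 3-fluorophenyl there, and in an assay on cells for inhibition of HSP60/HSP10 (Homo sapiens), with a stated time of 60 min (on this read-out higher numbers stand for weaker inhibition and lower numbers for stronger inhibition), compound 1 gives 71000 nM. Compound 3 `O=S(=O)(Nc1ccc(-c2nc3ccccc3o2)cc1)c1ccc(F)cc1` carries a 4-fluorophenyl instead, and in this assay compound 3 gives 73000 nM. Compound 2 `O=S(=O)(Nc1ccc(-c2nc3ccccc3o2)cc1)c1ccccc1Cl` carries a 2-chlorophenyl; for compound 2 this assay reports only a limit, > 100000 nM. Compound 3 thus sits at the higher of the two real numbers, but the gap a 1.0-fold higher number from compound 1 to compound 3 (0.01 log units; within the scatter) is within the scatter, so the two fluorophenyl compounds cannot be told apart. The comparison with the chlorophenyl compound, an at least 1.3-fold lower number from compound 2 to compound 3 (0.13 log units; that floor lies within the scatter), is only a floor, and that floor also lies within the scatter.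

Compound 4 `O=S(=O)(Nc1ccc(-c2nc3ccccc3o2)cc1)c1ccc(Cl)c(Cl)c1` is not yet measured. Its change from compound 3 is 3,4-dichlorophenyl in place of 4-fluorophenyl on a sulfonyl sulfur. Every measured step among the halogenated aryl groups, an at least 1.4-fold higher number from compound 1 to compound 2 (0.14 log units; that floor lies within the scatter) as well as the two already named, stays within the scatter, and one of the three values rests at the assay's ceiling, (the limit of > 100000 nM in this assay, at which 1 of the 3 values shown sits). A second chlorine is therefore expected to leave the weak inhibition roughly where it is, a 1.2-fold higher number from compound 3 to compound 4 (0.07 log units; within the scatter), with a real chance that compound 4 returns only a limit. The estimate for compound 4 in this assay is 85000 nM, within 30000 nM to 250000 nM.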

Compound 4, half-maximal inhibitory concentration: 25000 nM
Estimate against measurement, compound 4: 3.4-fold (0.53 log units) above; the measured number lies below the stated range.
By their numbers in this assay, from the lowest: compound 4; then compounds 1 and 3 (each within the scatter of the next). At a limit, above all of these: compound 2.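

Until now, every step at this aryl group on the sulfonyl sulfur lay within the scatter, so the position could have seemed indifferent to the choice of group, but in this assay the change to 3,4-dichlorophenyl gives the first readable steps (a 2.9-fold lower number from compound 3 to compound 4 (0.47 log units; beyond the scatter)) and (a 2.8-fold lower number from compound 1 to compound 4 (0.45 log units; beyond the scatter)). The position does respond to the aryl group, then, although both steps are modest and compound 4, at (25000 nM), remains a weak inhibitor in absolute terms. Compound 2 has only a limit, so its step is a floor (an at least 4.0-fold lower number from compound 2 to compound 4 (0.60 log units; beyond the scatter)), yet that floor also lies beyond the scatter, which shows that the presence of a chlorine on the ring does not by itself bring the lower number seen for compound 4.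

The compounds shown cannot say whether both chlorines are needed, since a 3-chlorophenyl or a 4-chlorophenyl group would be required to separate their contributions. They also leave open whether a different kind of group on this ring, such as a methoxy group, a carboxylic acid or an amine, would lower the number further.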